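A few compounds are considered here, and "the series" means these few. Any claim that something is new, unique, unknown or untested is made for them only; others in the source may bear on it.

Three hydrazone-linked compounds built on a shared indole core have been measured in a functional assay on MCF7 cells (Homo sapiens) for cytotoxicity; on this read-out lower numbers stand for stronger inhibition and higher numbers for weaker inhibition. Compound 1 `Cn1cc(C(=O)N/N=C\c2cn(Cc3ccc(Cl)cc3)c3cc(F)ccc23)c2ccccc21` gives 90600 nM; compound 2 `COc1ccc(Cn2cc(/C=N\NC(=O)c3c[nH]c4ccc(Br)cc34)c3ccc(F)cc32)cc1` gives 31700 nM; compound 3 `COc1ccc(Cn2cc(/C=N\NC(=O)c3c[nH]c4ccccc34)c3ccc(F)cc32)cc1` gives 13100 nM, the lowest of the three numbers, with the step of a 2.4-fold lower number from compound 2 to compound 3 (0.38 log units; beyond the scatter) taking it beyond compound 2 and compound 1 standing further away still. Compound 4 `COc1ccc(Cn2cc(/C=N\NC(=O)c3cn(C)c4ccccc34)c3ccc(F)cc32)cc1` differs from compound 3 by methyl in place of hydrogen on an aromatic nitrogen. Among the compounds with values here, no measured step tests exactly this change; the only pointer is that compound 1, which also carries a methyl on that nitrogen but differs elsewhere too, shows the highest number in this assay. Compound 4 is therefore expected to give a somewhat higher number, estimated at 25000 nM within 8000 nM to 80000 nM, a step of a 1.9-fold higher number from compound 3 to compound 4 (0.28 log units; within the scatter).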

Compound 4, half-maximal inhibitory concentration: 22600 nM
For compound 4 the middle estimate is 1.1-fold (0.04 log units) above the measured one; low and high end bracket the measured number.
By their numbers in this assay, from the lowest: compounds 3, 4 and 2 (each within the scatter of the next, the first and the last beyond it); then compound 1.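

In this assay, methyl in place of hydrogen on the aromatic nitrogen gives a 1.7-fold higher number from compound 3 to compound 4 (0.24 log units; within the scatter), so this position tolerates the methyl without a step beyond the scatter. Likewise, 1-methyl-1H-indol-3-yl in place of 5-bromo-1H-indol-3-yl gives a 1.4-fold lower number from compound 2 to compound 4 (0.15 log units; within the scatter), whereas with that methyl present in both compounds, methoxy in place of chloro gives a 4.0-fold lower number from compound 1 to compound 4 (0.60 log units; beyond the scatter), so the methyl alone does not carry the high number of compound 1. As far as these compounds go, whether an ethyl group or a longer chain on this nitrogen would behave like methyl stays open. No evidence at hand explains these numbers.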